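The compounds below may be only part of what the source reports. "The series", "measured", "known", "first", "only" and "open" are said of these compounds alone.

Measured so far:
Compound 1 `CN(C)C(=O)c1cc2cnc(Nc3ccc(NC(=O)C4(C(=O)Nc5ccccc5F)CC4)cc3)nc2n1C1CCCC1`: 82.6%
Compound 2 `CN(C)C(=O)c1cc2cnc(Nc3ccc(NC(=O)C4(C(=O)Nc5ccc(F)cc5)CC4)cc3F)nc2n1C1CCCC1`: 33%

In a functional assay on OVCAR-5 cells (Homo sapiens) for inhibition, read by CCK-8 assay, with a stated time of 72 h, tested at 10 uM (a lower number here means less inhibition of growth, a higher number more inhibition of growth at the concentration tested), compound 1 stands highest of the two numbers; its nearest neighbour, compound 2, gives 33%, a gap beyond the scatter. Compound 3 `CN(C)C(=O)c1cc2cnc(Nc3ccc(NC(=O)C4(C(=O)Nc5ccc(Br)cc5)CC4)cc3)nc2n1C1CCCC1` is not yet measured. It differs from compound 1 by 4-bromophenyl in place of 2-fluorophenyl on an amide-type nitrogen. Going by the values given here, no measured pair carries this single change, so its effect can only be expected. A moderate decrease is expected, a number 22.6 percentage points lower from compound 1 to compound 3 (beyond the scatter), because compound 2 with 33% shows that the substitution pattern on this ring matters. Compound 3 is estimated at 60%, ranging from 35% to 85%.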

Compound 3, percent growth inhibition at one concentration: 87.8%
Compound 3: middle estimate off by 27.8 percentage points, on the low side; measured number above the stated range.
By their numbers in this assay, from the lowest: compound 2; then compounds 1 and 3 (each within the scatter of the next).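

In this assay, 4-bromophenyl in place of 2-fluorophenyl on the amide-type nitrogen gives a number 5.2 percentage points higher from compound 1 to compound 3 (within the scatter). Going by these compounds alone, this is the first single change read at this position, and it shows that the two aryl groups cannot be told apart here, although both the halogen and its place on the ring differ. Nothing measured here offers an explanation for this result.

The effects of the halogen and its ring location remain unseparated, which a 4-fluorophenyl group on this nitrogen could address. From the compounds shown here alone, how a plain phenyl or a pyridine ring would read in this assay also remains open.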